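A few compounds are considered here, and "the series" means these few. Any claim that something is new, unique, unknown or untested is made for them only; others in the source may bear on it.

Series notes. Compound 1 `CCOC(=O)c1ccc2oc(N3CCN(C)CC3)nc2c1` and compound 2 `CCc1ccc2oc(N3CCN(C)CC3)nc2c1` share the core of compound 3 `CN1CCN(c2nc3cc(N)ccc3o2)CC1`. In a functional assay on ileum (strain Hartley) for agonist activity at 5-hydroxytryptamine receptor 3A (Cavia porcellus) (on this read-out lower numbers stand for lower potency and higher numbers for higher potency (the scale is a negative logarithm)), compound 1 gives only a limit of the assay, < 4. Compound 2 likewise gives only a limit in this assay, < 4. Among the measured compounds shown here, compound 3 is the single member with a number in this assay, 4.97, and so holds the only readable point in the set.

Of the measured steps, a step that the two limits leave unreadable from compound 1 to compound 2 cannot be read from the two limits. The two steps into compound 3 can: a number at least 0.97 log units higher from compound 1 to compound 3 (beyond the scatter) and a number at least 0.97 log units higher from compound 2 to compound 3 (beyond the scatter), both beyond the scatter, and both carry the amino group in.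

Compound 4 `CN1CCN(c2nc3cc(Br)ccc3o2)CC1` is not yet measured. It differs from compound 3 by bromo in place of amino on an aromatic carbon. For the measured compounds named here, no measured step carries bromo, so the steps into compound 3 bear on it only by showing what the amino group brought; compound 4 removes that group, and the two earlier compounds lacking it sit at the limit (the limit of < 4 in this assay, at which 2 of the 3 values shown sit). A step downward beyond the scatter is therefore expected, a number 0.67 log units lower from compound 3 to compound 4 (beyond the scatter), with a real chance that this assay again returns only a limit. Compound 4 is expected at 4.3, within 3.6 to 5.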

Compound 4, negative logarithm of the half-maximal effective concentration: 6.21
The estimate for compound 4 lay 1.91 log units below the measured number, and the stated range ends below it.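

The amino group is not needed for a readable number at this position: a number 1.24 log units higher from compound 3 to compound 4 (beyond the scatter) in this assay, so the hydrogen-bond donor and acceptor counted on amino are not required, and bromo, which carries neither, does better. The same place also separates bromo from the two larger substituents, with a number at least 2.21 log units higher from compound 2 to compound 4 (beyond the scatter) and a number at least 2.21 log units higher from compound 1 to compound 4 (beyond the scatter), and both of these steps rest on a limit on the side of compound 1 and compound 2 rather than on a number. Within these four compounds the position therefore gives a clear order, with bromo over amino and both over ethyl and ethoxycarbonyl, and only the two groups entering as a single heavy atom give numbers, while the other two stay at the floor of the read-out: the limit of < 4 in this assay, at which 2 of the 4 values shown sit.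

Open, from the compounds shown here alone, is whether chloro, iodo, methyl or hydroxy at this aromatic carbon would follow bromo, stay near amino or fall to the limit, which would show whether the gain belongs to bromo itself or to a wider set of small groups. The compounds shown vary this one place only, so whether the step holds with the rest of the shared core changed remains unknown.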